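The source may hold more compounds than are shown below. What is called first, only, known or untested is meant among the compounds shown, and "the series" means these compounds.

Of the compounds shown here, three of this set have been measured for inhibition of the enzyme in an assay on H4 cells for inhibition of Fatty-acid amide hydrolase 1 (Homo sapiens); on this read-out lower numbers stand for stronger inhibition and higher numbers for weaker inhibition. Compound 1, `CCCCOc1ccc(CNC(=O)Oc2ccc(F)cc2F)cc1`, gives 8.7 nM, and compound 2, `CCCCOc1ccc(CNC(=O)Oc2ccc(F)cc2)cc1`, gives 4.6 nM. The two differ by one change, (fluoro in place of hydrogen on an aromatic carbon), and this change brought a 1.9-fold higher number from compound 2 to compound 1 (0.28 log units; within the scatter), a step that stays within the usual scatter of the measurement. Compound 3, `CCOc1ccc(NC(=O)O/N=C/c2ccccc2)cc1`, is built on a different core; in this assay compound 3 gives 81 nM, the highest of the three numbers, and its gap to both compound 1 and compound 2 lies beyond the scatter. How the core of compound 3 differs from the core of compound 2 is not broken down here.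

Compound 4, `CCOc1ccc(NC(=O)O/N=C/c2ccc(F)cc2)cc1`, has not yet been measured. It comes from compound 3 through (fluoro in place of hydrogen on an aromatic carbon). Among the measured compounds shown here, this is the same kind of change as the one from compound 2 to compound 1, though not the same: in compound 4 the fluoro enters para to a large group, whereas in compound 1 it entered ortho to a large group and meta to a fluoro group. For the measured compounds named here, because the only measured example of this kind of change, a 1.9-fold higher number from compound 2 to compound 1 (0.28 log units; within the scatter), stayed within the scatter, the step from compound 3 to compound 4 is expected to be small as well, a 1.2-fold lower number from compound 3 to compound 4 (0.10 log units; within the scatter). On that basis compound 4 is estimated at 65 nM in this assay, with a likely range from 25 nM to 170 nM.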

Compound 4, half-maximal inhibitory concentration: 46 nM
Compound 4: middle estimate off by 1.4-fold (0.15 log units), on the high side; measured number inside the range.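

In this assay, fluoro in place of hydrogen gave a 1.8-fold lower number from compound 3 to compound 4 (0.25 log units; within the scatter), and set beside the earlier case the same change moved the number in opposite directions on the two cores, by an amount that separates them: the same change on two cores in this assay, a 1.9-fold higher number (0.28 log units; within the scatter) from compound 2 to compound 1 and a 1.8-fold lower number (0.25 log units; within the scatter) from compound 3 to compound 4, 3.3-fold (0.52 log units) apart, beyond the scatter of two such steps. This shows that, in this series, the change cannot be carried from one core to the other as a fixed shift of known direction, even though each step taken alone stays within the scatter and so does not establish a real effect of the fluoro on its core. Among the compounds shown here, it does not show that the core is what sets the two steps apart, since only two pairs are available and the fluoro does not enter the same kind of place in both: in compound 4 it lies para to a large group, while compound 1 has a different arrangement, so core and place cannot be separated here.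

The compounds shown leave open whether a chloro or a methoxy group at that same place on the phenyl of compound 3 would move the number further than fluoro does. They also leave open which direction the fluoro step would take on a third core, or with the fluoro at another place on the same ring.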